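A few compounds are considered here, and "the series" means these few. Any claim that something is new, unique, unknown or untested is made for them only; others in the source may bear on it.

Working notes on the series. In an ADME assay on J774.A1 cells (Mus musculus) for cytotoxicity, read by MTT assay, with a stated time of 72 h (on this read-out higher numbers stand for lower toxicity in this test and lower numbers for higher toxicity in this test), compound 1 (`COc1cc(C(Nc2ccc(C3(C)NC(=O)c4ccccc4N3)cc2)c2nnnn2C(C)(C)C)cc(OC)c1OC`) stands at "not determined" (no result reported) and so offers no number as a starting point. Compound 2 (`CC(C)(C)n1nnnc1C(c1ccc(C2NC(=O)c3ccccc3N2)cc1)N1CCc2ccccc2C1`) is in the same position at "not determined" (no result reported) with nothing to compare. Within the data shown here, compound 3 (`CCCCNc1nc(NCCCC)nc(Nc2ccc(C3(C)NC(=O)c4ccccc4N3)cc2)n1`) gives 40100 nM as the only number available.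

Compound 4 (`COc1ccc(C(Nc2ccc(C3(C)NC(=O)c4ccccc4N3)cc2)c2nnnn2C(C)(C)C)cc1`) departs from compound 1 by one change: 4-methoxyphenyl in place of 3,4,5-trimethoxyphenyl on a saturated chain carbon bound to an aromatic carbon and a nitrogen on an aromatic ring.

Among the measured compounds shown here, no measured step exists to size this change. In this assay a step beyond the usual scatter is therefore not expected, and no direction is assigned. For the measured compounds named here, the only anchor is compound 3 at 40100 nM in a structure that differs from compound 4 in more than one place, so the range is kept wide. For compound 4 the estimate is 35000 nM with an expected range from 10000 nM to 100000 nM in this test.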

Compound 4, half-maximal cytotoxic concentration: > 400000 nM
Compound 4: a limit, no number; the forecaster's own chance of this, stated with the estimate: 30%; middle value at least 11-fold (1.05 log units) away from the limit.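

In this assay compound 4 gives > 400000 nM, which is a limit and not a number. With no number for compound 1 either, no step can be read between compound 1 and compound 4. The compounds shown leave open what 4-methoxyphenyl in place of 3,4,5-trimethoxyphenyl does to the half-maximal cytotoxic concentration.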